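The source may hold more compounds than are shown below. What is called first, only, known or untested is meant among the compounds shown, and "the series" means these compounds.

Measured so far in an ADME assay on microsomes from liver (Rattus norvegicus) for metabolic stability, with a stated time of 10 min; a lower number here means that less of the compound is left, a higher number that more of the compound is left:
Compound 1 `CNC(=O)c1nnc(NC(=O)C2CC2)cc1Nc1cccc(-c2cnccn2)c1OC`: 1%
Compound 2 `CNC(=O)c1nnc(NC(=O)C2CC2)cc1Nc1cccc(-c2cnc(C(C)(C)O)cn2)c1OC`: 90%

Compound 2 holds the higher of these two numbers at 90%, well clear of compound 1 at 1% in this assay. The next compound to be measured is compound 3 `CNC(=O)c1nnc(NC(=O)C2CC2)cc1Nc1cccc(-c2ccccn2)c1OC`, which shares the core of compound 2. It carries pyridin-2-yl in place of 5-(1-hydroxy-1-methylethyl)pyrazin-2-yl on an aromatic carbon, ortho to a methoxy group: pyridin-2-yl in place of 5-(1-hydroxy-1-methylethyl)pyrazin-2-yl on an aromatic carbon.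

Within the data shown here, one measured step bears on this change, and it is a large one: 1-hydroxy-1-methylethyl in place of hydrogen on an aromatic carbon gave a number 89 percentage points higher from compound 1 to compound 2 (beyond the scatter). Compound 3 lacks that group, as compound 1 does, so the same large step is expected to run the other way. Among the measured compounds shown here, no measured step shows what the exchange of the ring for pyridin-2-yl does by itself, which leaves some room upward. A large drop is therefore expected, an estimated a number 85 percentage points lower from compound 2 to compound 3 (beyond the scatter). The estimate for compound 3 is 5%, with the result expected between 0% and 25%.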

Compound 3, percent of the compound remaining: 34%
For compound 3 the middle estimate is 29 percentage points below the measured one; measured number above the stated range.
By their numbers in this assay, from the lowest: compound 1; then compound 3; then compound 2.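

In this assay, the ring itself proves to matter at this aromatic carbon, ortho to a methoxy group, which the earlier pair could not show: with no 1-hydroxy-1-methylethyl group on either compound, pyridin-2-yl in place of pyrazin-2-yl gave a number 33 percentage points higher from compound 1 to compound 3 (beyond the scatter). Even so, the pyridin-2-yl group does not match the substituted ring, as pyridin-2-yl in place of 5-(1-hydroxy-1-methylethyl)pyrazin-2-yl gave a number 56 percentage points lower from compound 2 to compound 3 (beyond the scatter), so the gain from the ring exchange accounts for only part of the distance between the unsubstituted pyrazin-2-yl compound and the best of the three. Nothing available here explains either step.

The compounds shown leave open whether 1-hydroxy-1-methylethyl on a pyridin-2-yl ring would raise the number as it did on pyrazin-2-yl, and so whether the effects of the ring and of the group add up or overlap. They also leave open whether the hydroxyl of that group is needed, which a plain isopropyl, a methoxy or an amine carried on the same ring could begin to answer.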